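The source may report more compounds than this note shows. Statements on the series, on what has been measured and on what is new or still open speak of the compounds shown alone.

Compound 3 `Cc1ccc(S(=O)(=O)NC(=O)/C=C/c2ccc([N+](=O)[O-])cc2)cc1` gives 13.5 ug/mL in a functional assay on B16-F10 cells (Mus musculus) for antiproliferative activity, read by ELISA and MTT assay, with a stated time of 48 h (a higher number here means a weaker inhibitor, a lower number a stronger inhibitor), the highest of the three numbers in hand. Compound 2 `CN(C)c1ccc(/C=C/C(=O)NS(=O)(=O)c2ccc(Cl)cc2)cc1` gives 2.8 ug/mL and compound 1 `O=C(/C=C/c1ccc(Cl)cc1)NS(=O)(=O)c1ccc(Cl)cc1` gives 2.5 ug/mL; both values lie beyond the scatter from that of compound 3, and the two of them sit within the scatter of each other. Among the measured compounds shown here, the only step measured within the set, a 1.1-fold higher number from compound 1 to compound 2 (0.05 log units; within the scatter), concerns a substituent on the other aromatic ring of the shared core and is within the scatter. Compound 4 `O=C(/C=C/c1ccc([N+](=O)[O-])cc1)NS(=O)(=O)c1ccc(Cl)cc1` has not yet been measured; it differs from compound 3 by chloro in place of methyl on an aromatic carbon. For the measured compounds named here, no measured step touches this ring, so the step from compound 1 to compound 2 bears on it only indirectly, showing that one exchange elsewhere on the core left this assay unmoved. Compound 4 shares the changed ring with compound 1 and compound 2, whose values are lower than that of compound 3. The step from compound 3 to compound 4 is therefore expected to be small and of uncertain direction, a 1.5-fold lower number from compound 3 to compound 4 (0.18 log units; within the scatter). For compound 4 the value in this assay is estimated at 9 ug/mL, within a range of 3.5 ug/mL to 22 ug/mL.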

Compound 4, half-maximal inhibitory concentration: 13.7 ug/mL
For compound 4 the middle estimate is 1.5-fold (0.18 log units) below the measured one, and the stated range covers the measured number.
By their numbers in this assay, from the lowest: compounds 1 and 2 (each within the scatter of the next); then compounds 3 and 4 (each within the scatter of the next).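

In this assay, the change from 4-methylphenyl to 4-chlorophenyl, with nitro held on the other aromatic ring, leaves the reading unmoved: a 1.0-fold higher number from compound 3 to compound 4 (0.01 log units; within the scatter). With 4-chlorophenyl held fixed, the substituent on the other ring does register, giving a 5.5-fold higher number from compound 1 to compound 4 (0.74 log units; beyond the scatter) for nitro in place of chloro and a 4.9-fold higher number from compound 2 to compound 4 (0.69 log units; beyond the scatter) for nitro in place of dimethylamino, while chloro and dimethylamino remain indistinguishable, with a 1.1-fold higher number from compound 1 to compound 2 (0.05 log units; within the scatter). Among the compounds shown, the sensitivity therefore lies in nitro on that ring rather than in the methyl-to-chloro exchange, and no supporting data explain either result.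

As far as these compounds go, whether the methyl-to-chloro exchange stays as silent with chloro or dimethylamino on the other ring remains open. From the compounds shown here alone, the effect of a primary amine or a carboxylic acid at either site is also open.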